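A few compounds are considered here, and "the series" means these few. Any claim that something is new, unique, unknown or untested is made for them only; others in the source may bear on it.

Measured in a functional assay on Caco-2 cells (Homo sapiens), read by MTT assay, with a stated time of 48 h; a lower number here means a stronger inhibitor, a higher number a weaker inhibitor:
- compound 1 `CCn1c(C(=O)NCCN(C)C)ccc1C(CC)(CC)c1ccc(OCC(O)C(C)(C)C)c(C)c1`: 1300 nM
- compound 2 `CCn1c(C(=O)N(CCC#N)CCC#N)ccc1C(CC)(CC)c1ccc(OCC(O)C(C)(C)C)c(C)c1`: 7100 nM

Not yet measured:
- compound 3 `CCn1c(C(=O)Oc2ccc(CCO)cc2)ccc1C(CC)(CC)c1ccc(OCC(O)C(C)(C)C)c(C)c1`

Compound 2, at 7100 nM, holds the higher of the two numbers, which makes it the weaker inhibitor of the pair in this assay. The next structural change again falls on a carbonyl carbon, one whose other neighbours are an aromatic carbon: a group of 10 heavy atoms (8 carbon, 2 oxygen; one six-membered aromatic ring of carbon only) in place of a group of 9 heavy atoms (6 carbon, 3 nitrogen; no ring), on a carbonyl carbon. The group that enters has one six-membered aromatic ring of carbon only, while the group that leaves has no ring.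

Within the data shown here, only one measured step bears on this change, since it also swaps the group on that carbonyl carbon: a 5.5-fold higher number from compound 1 to compound 2 (0.74 log units; beyond the scatter). It was modest and lay beyond the scatter. Neither measured compound has a ring in this group, so the direction remains uncertain. A modest step is expected, leaning towards a lower number in this assay since compound 2 sits at 7100 nM, the top of the measured values. The expected change is a 2.0-fold lower number from compound 2 to compound 3 (0.31 log units; beyond the scatter). For compound 3 the estimate is 3500 nM, with an expected range from 900 nM to 13000 nM.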

Compound 3, half-maximal inhibitory concentration: > 50000 nM
Compound 3: no number, only a limit; the forecaster's own chance of this, stated with the estimate: 10%; at least 14-fold (1.15 log units) between middle value and limit.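

Compound 3 has no number in this assay, only a limit of the assay: the limit of > 50000 nM in this assay, at which 1 of the 3 values shown sits. With one six-membered aromatic ring of carbon only in the group on this carbonyl carbon, the read-out shows an at least 7.0-fold higher number from compound 2 to compound 3 (0.84 log units; beyond the scatter), and the comparison with the smaller ring-free group of the first compound gives an at least 38-fold higher number from compound 1 to compound 3 (1.58 log units; beyond the scatter). The two ring-free groups had shown only a modest shift at this position, whereas this new group takes the result beyond what the assay could put a number on, so the choice of group here can matter far more than the earlier pair showed.

The entering group differs from the leaving one in several ways at once, including its ring, its oxygen atoms and its hydrogen-bond donor, and the three compounds cannot show which of these differences counts. An amide carrying a plain phenyl ring, or a longer chain ending in an amine, would be the kind of group that could begin to separate these features.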